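The compounds below may be only part of what the source reports. "The series", "measured", "known", "first", "only" and "open" are said of these compounds alone.

In an ADME assay on the whole organism (brain, Rattus norvegicus, strain Sprague-Dawley) for protein binding, read by LC-MS, using cassette dosing, with a stated time of 24 h (a higher number here means a larger unbound share of the compound, a lower number a smaller unbound share), compound 1 `COc1cc(C(=O)Nc2cc(OC(F)(F)F)ccc2-n2cncn2)ccc1OCC1CC1` gives < 0.003, a limit of the assay and not a number. Compound 2 `COc1ccc(CCCNc2cc(OC(F)(F)F)ccc2-n2cncn2)cc1OC` gives < 0.003, which is also a limit. All that is known so far is the limit of < 0.003 in this assay, at which 2 of the 2 values shown sit. Compound 3 `COc1cc(F)c(CCCNc2cc(OC(F)(F)F)ccc2-n2cncn2)cc1OC` is compound 2 with fluoro in place of hydrogen on an aromatic carbon. Among the measured compounds shown here, no measured pair shows what such a change does. No step beyond the usual scatter is expected in this assay, in either direction. The expected change is a step that the limit leaves unreadable from compound 2 to compound 3. For compound 3 the estimated value is 0.002, with an expected range from 0.001 to 0.004.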

Compound 3, unbound fraction: < 0.003
Compound 3: no number, only a limit; the forecaster's own chance of this, stated with the estimate: 75%; the middle value lies beyond the limit too.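

In this assay compound 3 gives < 0.003, a limit and not a number. Among the compounds shown here, compound 2 also sits at a limit, so no step from compound 2 to compound 3 can be read. From the compounds shown here alone, the true unbound share of each compound, and what the fluoro group does to it, stays open.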